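The source may hold more compounds than are shown below. What is called first, only, known or untested is meant among the compounds shown, and "the series" means these compounds.

In an ADME assay (liver) for metabolic stability, with Liver microsome (Rattus norvegicus) as the target, using microsomes (on this read-out higher numbers stand for fast clearance and lower numbers for slow clearance), two compounds have been read so far. Compound 1 `CN(C(=O)c1ccncc1)c1ccc(OCB2C=Cc3ccccc3N2)cc1` gives 115 mL/min/kg. Compound 2 `CN(C(=O)c1csc(-c2cccnc2)n1)c1ccc(OCc2ccc3ccccc3n2)cc1` gives no exact number, only a limit of the assay: > 283 mL/min/kg. That places compound 2 at the limit of > 283 mL/min/kg in this assay, at which 1 of the 2 values shown sits.

Compound 3 `CN(C(=O)c1csc(-c2cccnc2)n1)c1ccc(OCc2ccc3ccccc3c2)cc1` is compound 2 with one change: naphthalen-2-yl in place of quinolin-2-yl on a saturated chain carbon bound to an oxygen on an aromatic ring. In words, naphthalen-2-yl takes the place of quinolin-2-yl, on a saturated chain carbon bound to an oxygen on an aromatic ring. The rest of the molecule stays the same.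

Going by the values given here, no measured pair in this small set differs in only one place, so the data do not show directly what this swap does to clearance. Among the compounds with values here, the only close guide is compound 2, with its limit of > 283 mL/min/kg, so fast clearance is expected to persist in compound 3. The estimated step, an at least 1.1-fold lower number from compound 2 to compound 3 (0.05 log units; that floor lies within the scatter), is expected to stay within the scatter, and compound 3 may also return only a limit. For compound 3 the expected clearance is 250 mL/min/kg, within an estimated range of 120 mL/min/kg to 420 mL/min/kg.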

Compound 3, clearance: > 283 mL/min/kg
Compound 3: a limit, no number (the forecaster's own chance of this, stated with the estimate: 50%); middle value at least 1.1-fold (0.05 log units) away from the limit.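

In this assay, going by these compounds alone, compound 2 and compound 3 each return only a limit of the assay and not a number, so no step between compound 2 and compound 3 can be read: the limit of > 283 mL/min/kg in this assay, at which 2 of the 3 values shown sit.

The compounds shown leave open how far the clearance of either compound lies beyond that limit, and whether swapping quinolin-2-yl for naphthalen-2-yl changes it at all.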